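Compound 1 to compound 3: losing the phenyl

This account rests on a few compounds, and the source may have more. Where it says the series, first, only, none or still open, it means among the compounds named here.

Measured so far in a functional assay on HT-29 cells (Homo sapiens) for antiproliferative activity, read by sulforhodamine B assay, with a stated time of 72 h; a higher number here means a weaker inhibitor, a lower number a stronger inhibitor
compound 1 `S=C(NNc1nncc2ccccc12)Nc1ccccc1` gives 40 nM
compound 2 `COc1ccc(NC(=S)NNc2nncc3ccccc23)cc1` gives 20 nM

Among the measured compounds shown here, compound 1 lies within the scatter of compound 2, the only other compound measured in this assay here. Compound 3 `NC(=S)NNc1nncc2ccccc12` carries hydrogen in place of phenyl on an amide-type nitrogen. For the measured compounds named here, one measured step bears on this, a 2.0-fold lower number from compound 1 to compound 2 (0.30 log units; within the scatter), and it retains the phenyl, so no measurement shows what losing that group does. This larger change is expected to raise the number, with wide uncertainty. The estimated change is a 3.8-fold higher number from compound 1 to compound 3 (0.57 log units; beyond the scatter) and remains an expectation only. Compound 3 is expected at 150 nM within an estimated range (40 nM to 600 nM).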

Compound 3, half-maximal inhibitory concentration: 47 nM
Estimate against measurement, compound 3: 3.2-fold (0.50 log units) above, within the range that was stated.
By their numbers in this assay, from the lowest: compounds 2, 1 and 3 (each within the scatter of the next, the first and the last beyond it).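

In this assay, the anilino to amino change on this amide-type nitrogen stays within the scatter: a 1.2-fold higher number from compound 1 to compound 3 (0.07 log units; within the scatter). The earlier compounds shown here all retained the phenyl, whereas this pair shows that a value in this range does not depend on that group, at least between these two compounds. No available evidence accounts for this result.

On these data alone, it remains open whether a methyl, a longer chain or a cyclohexyl on this nitrogen would also read within the scatter of compound 3. As far as these compounds go, the effect of a carboxylic acid on the phenyl of compound 1 also remains open.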